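Methoxy for nitro in a weak inhibitor series

This account rests on a few compounds, and the source may have more. Where it says the series, first, only, none or still open, it means among the compounds named here.

Compound 1 `O=C(CCc1nc2ccccc2c(=O)[nH]1)N/N=C/c1ccc([N+](=O)[O-])cc1` gives 220000000 nM
Compound 2 `COc1cc(/C=N/NC(=O)CCCc2nc3ccccc3c(=O)[nH]2)cc(OC)c1OC` gives 60000000 nM
Compound 3 `O=C(CCCc1nc2ccccc2c(=O)[nH]1)N/N=C/c1ccc([N+](=O)[O-])cc1` gives 270000000 nM

All three values come from a physicochemical assay, read by spectrophotometry, with a stated time of 6 min (on this read-out lower numbers stand for stronger inhibition and higher numbers for weaker inhibition), and none of them is a limit. Compound 1 at 220000000 nM and compound 3 at 270000000 nM lie within the usual scatter of each other. The number of compound 1 is higher than that of compound 2, and that gap lies beyond the scatter.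

Compound 4 `COc1ccc(/C=N/NC(=O)CCc2nc3ccccc3c(=O)[nH]2)cc1` has not yet been measured. It differs from compound 1 in one place (methoxy in place of nitro on an aromatic carbon), with methoxy in place of nitro on an aromatic carbon, turning 4-nitrophenyl into 4-methoxyphenyl.

Among the compounds with values here, no measured pair isolates this change. Compound 3 carries nitro and reads 270000000 nM while compound 2 carries methoxy groups and reads 60000000 nM so a lower number is expected, though compound 2 also differs from compound 1 elsewhere. The estimated step of a 2.2-fold lower number from compound 1 to compound 4 (0.34 log units; beyond the scatter) is a modest one toward a lower number, near the edge of the scatter. Compound 4 is expected at 100000000 nM with an estimated range of 40000000 nM to 260000000 nM when tested.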

Compound 4, half-maximal inhibitory concentration: 75000000 nM
Estimate against measurement, compound 4: 1.3-fold (0.12 log units) above, within the range that was stated.
By their numbers in this assay, from the lowest: compounds 2 and 4 (each within the scatter of the next); then compounds 1 and 3 (each within the scatter of the next).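

At this position, on an aromatic carbon para to a large group, methoxy in place of nitro gives a 2.9-fold lower number from compound 1 to compound 4 (0.47 log units; beyond the scatter) in this assay. This is the only pair shown that isolates the change, so the shift toward a lower number no longer rests on compounds that also differ elsewhere. The step is modest but clears the scatter, which shows that this one substitution can move the read-out on the shared core. Nothing measured here accounts for the step.

The compounds shown leave open how other groups at this position would read, such as an amine, a chlorine atom or a carboxylic acid. They also leave open whether methoxy in place of nitro gives a step of similar size on the longer chain of compound 3.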